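Swapping the sulfonyl side chain of compound 3 for amino

The compounds below may be only part of what the source reports. "The series", "measured", "known", "first", "only" and "open" are said of these compounds alone.

In an ADME assay on microsomes from liver (Mus musculus) for metabolic stability, read by LC-MS, using NADPH, with a stated time of 30 min, tested at 0.1 uM (on this read-out lower numbers stand for a less stable compound and higher numbers for a more stable compound), compound 1 (`CS(=O)(=O)Nc1ccc2nccc(-c3ccncc3)c2n1`) gives 95%, compound 2 (`O=S(=O)(CCO)c1cccc(-c2ccc3nccc(-c4ccncc4)c3n2)c1`) gives 52% and compound 3 (`O=S(=O)(c1cccc(-c2ccc3nccc(-c4ccncc4)c3n2)c1)N1CC[C@H](O)C1`) gives 12%. Compound 3 is thus the lowest of the three, beyond the scatter from both others. Compound 4 (`Nc1cccc(-c2ccc3nccc(-c4ccncc4)c3n2)c1`) carries amino in place of (3-hydroxypyrrolidin-1-yl)sulfonyl on an aromatic carbon. Within the data shown here, the only measured step that bears on this change is large: a number 40 percentage points lower from compound 2 to compound 3 (beyond the scatter). Among the measured compounds shown here, it alters the group on the sulfonyl sulfur, and no measured step removes the sulfonyl group itself, so the guidance is indirect. The expected change is a large rise, a number 28 percentage points higher from compound 3 to compound 4 (beyond the scatter). Compound 4 is estimated at 40%, with an expected range from 15% to 75%.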

Compound 4, percent of the compound remaining: 54%
Compound 4: the middle estimate sits 14 percentage points below what was measured; the range from low to high includes it.
By their numbers in this assay, from the lowest: compound 3; then compounds 2 and 4 (each within the scatter of the next); then compound 1.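

In this assay, the bare amino group on this aromatic carbon recovers the loss seen with (3-hydroxypyrrolidin-1-yl)sulfonyl (a number 42 percentage points higher from compound 3 to compound 4 (beyond the scatter)), while it cannot be told apart from (2-hydroxyethyl)sulfonyl (a number 2 percentage points higher from compound 2 to compound 4 (within the scatter)). Compound 4 still falls well short of the compound with methanesulfonamido in place of 3-aminophenyl (a number 41 percentage points lower from compound 1 to compound 4 (beyond the scatter)). No measurement on hand explains these steps.

Open, going by these compounds, is how acetamido or dimethylamino on the same carbon would read, and whether a carboxylic acid there would keep the level of compound 4.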